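The source may hold more compounds than are shown below. What is called first, only, known or untested is meant among the compounds shown, and "the series" means these compounds.

Of the compounds shown here, three have been measured in an assay on HEK293 cells for binding affinity to 5-hydroxytryptamine receptor 7 (Homo sapiens), read by radioligand binding, tested at 1 uM; a lower number here means less inhibition, a higher number more inhibition at the concentration tested (going by the name of the read-out). Compound 1 `Brc1ccc2ccn(CCN3CCN4CCCCC4C3)c2c1` gives 78%, compound 2 `Brc1cccc2ccn(CCN3CCN4CCCCC4C3)c12` gives 13%, and compound 3 `CN1CCCN(CCn2ccc3ccc(F)cc32)CC1` gives 60%. On these numbers compound 3 stands second highest of three; the nearest number is that of compound 1, higher by a margin beyond the scatter, and the furthest is that of compound 2, lower by a margin beyond the scatter. Compound 4 `C#Cc1ccc2ccn(CCN3CCCN(C)CC3)c2c1` differs from compound 3 in one place: ethynyl in place of fluoro on an aromatic carbon. Within the data shown here, no measured pair carries this change, so its size in this assay is open. The step expected in this assay, a number 3 percentage points higher from compound 3 to compound 4 (within the scatter), is none beyond the scatter, with a slight lean upward. Compound 4 is estimated at 63%, within 42% to 82%.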

Compound 4, a percentage reported as inhibition, at one concentration (the size of the read-out at that concentration, not a potency): 79%
Estimate against measurement, compound 4: 16 percentage points below; the range from low to high includes it.
By their numbers in this assay, from the lowest: compound 2; then compound 3; then compounds 1 and 4 (each within the scatter of the next).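

Among these compounds, with ethynyl in place of fluoro on this aromatic carbon, this assay shows a number 19 percentage points higher from compound 3 to compound 4 (beyond the scatter) and gives the first step between compounds that differ in one place. The number at this position therefore depends on which of these two groups it carries, and the larger ethynyl group is accommodated without loss. Nothing shown bears on the reason for this step.

As far as these compounds go, whether a nitrile or a methoxy group on the same carbon would behave like ethynyl remains open. So does whether the step carries over to the amine side chain of compound 1.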